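The compounds below may be only part of what the source reports. "The series", "measured", "known", "first", "only" and "open" are said of these compounds alone.

Compound 1 `Cn1cc(-c2nc3ccccc3n2C(=O)c2ccccc2Br)c2ccccc21`, compound 2 `Cn1cc(-c2nc3ccccc3n2C(=O)c2cccc(Br)c2)c2ccccc21` and compound 3 `COc1ccc2c(c1)c(-c1nc3ccccc3n1C(=O)c1ccccc1Br)cn2C` share a common framework and were all tested in a functional assay on HepG2 cells (Homo sapiens) for inhibition, read by MTT assay, with a stated time of 24 h; a higher number here means a weaker inhibitor of growth, a lower number a stronger inhibitor of growth. In this assay compound 1 gives 68200 nM, compound 2 gives 61400 nM and compound 3 gives 54200 nM. The three values sit close to one another.

Compound 2 differs from compound 1 in a single place: 3-bromophenyl in place of 2-bromophenyl on a carbonyl carbon. That change produced a 1.1-fold lower number from compound 1 to compound 2 (0.05 log units; within the scatter). Compound 3 differs from compound 1 in its core: methoxy in place of hydrogen on an aromatic carbon. This difference produced a 1.3-fold lower number from compound 1 to compound 3 (0.10 log units; within the scatter).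

Compound 4 `COc1ccc2c(c1)c(-c1nc3ccccc3n1C(=O)c1cccc(Br)c1)cn2C` has not yet been measured. It differs from compound 3 in one place: 3-bromophenyl in place of 2-bromophenyl on a carbonyl carbon. For the measured compounds named here, this is the same change as the one that turns compound 1 into compound 2, now made on the core of compound 3 rather than on the core of compound 1; the surroundings of the place are the same word for word in both pairs. Among the compounds considered here this change occurs twice. Resting on a 1.1-fold lower number from compound 1 to compound 2 (0.05 log units; within the scatter), a step of comparable size is expected for compound 4, namely a 1.1-fold lower number from compound 3 to compound 4 (0.04 log units; within the scatter). In this assay compound 4 is therefore estimated at 50000 nM, with a likely range from 27000 nM to 95000 nM.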

Compound 4, concentration for 50% growth inhibition: 51300 nM
The estimate for compound 4 lay 1.0-fold (0.01 log units) below the measured number, and the stated range covers the measured number.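

In this assay, 3-bromophenyl in place of 2-bromophenyl on a carbonyl carbon gives a 1.1-fold lower number from compound 3 to compound 4 (0.02 log units; within the scatter), and this step agrees with the one seen on the core of compound 1: the same change on two cores in this assay, a 1.1-fold lower number (0.05 log units; within the scatter) from compound 1 to compound 2 and a 1.1-fold lower number (0.02 log units; within the scatter) from compound 3 to compound 4, 1.1-fold (0.02 log units) apart, within the scatter of two such steps

Methoxy in place of hydrogen on an aromatic carbon gives a 1.2-fold lower number from compound 2 to compound 4 (0.08 log units; within the scatter), and this step likewise agrees with its earlier counterpart: the same change on two cores in this assay, a 1.3-fold lower number (0.10 log units; within the scatter) from compound 1 to compound 3 and a 1.2-fold lower number (0.08 log units; within the scatter) from compound 2 to compound 4, 1.1-fold (0.02 log units) apart, within the scatter of two such steps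

All four steps lie within the scatter, so the two changes carry over only in the sense that neither gives a step beyond the scatter on either core; this does not show that a change with a clear effect would carry over in the same way, and it says nothing about cores other than these two.

All four compounds keep a bromine on the phenyl group and carry either hydrogen or methoxy at the one varied place on the core, which leaves open whether a nitrile, an amine or a carboxylic acid in place of the bromine, or a longer chain in place of the methoxy, would give a step beyond the scatter. Also open, on these data alone, is whether such a step, if one appeared, would keep its size between the core of compound 1 and the core of compound 3.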